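Replacing Propyl with 2-Cyclohexylethenyl: An Expected Gain

The source may report more compounds than this note shows. Statements on the series, on what has been measured and on what is new or still open speak of the compounds shown alone.

Measured in an assay on CHO cells for antagonist activity at transient receptor potential cation channel subfamily V member 1 (Homo sapiens), read by FLIPR and calcium flux; on this read-out higher numbers stand for weaker inhibition and lower numbers for stronger inhibition:
- Compound 1, `CCCc1nc(C(F)(F)F)ccc1CNC(=O)C(C)c1ccc(NS(C)(=O)=O)c(F)c1`: compound 1 gives 22.7 nM
- Compound 2, `CC(C(=O)NCc1ccc(C(F)(F)F)nc1C1CC2CCC1C2)c1ccc(NS(C)(=O)=O)c(F)c1`: compound 2 gives 1.5 nM
- Compound 3, `CCC/C=C/c1nc(C(F)(F)F)ccc1CNC(=O)C(C)c1ccc(NS(C)(=O)=O)c(F)c1`: compound 3 gives 0.9 nM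

Compound 1 stands highest of the three numbers; its nearest neighbour is compound 2, and the further one is compound 3. Compound 4, `CC(C(=O)NCc1ccc(C(F)(F)F)nc1/C=C/C1CCCCC1)c1ccc(NS(C)(=O)=O)c(F)c1`, differs from compound 1 at one place: 2-cyclohexylethenyl in place of propyl on an aromatic carbon. Within the data shown here, two measured steps bear on this change, both starting from compound 1 and both enlarging the group on the same aromatic carbon. There was a 25-fold lower number from compound 1 to compound 3 (1.40 log units; beyond the scatter), where a double bond outside the aromatic ring enters, and a 15-fold lower number from compound 1 to compound 2 (1.18 log units; beyond the scatter), where rings of carbon enter. Between those two products the difference was small, a 1.7-fold lower number from compound 2 to compound 3 (0.22 log units; within the scatter). The entering group of compound 4 carries both a double bond outside aromatic rings and a ring of carbon, so a large downward step is expected in this assay, a 19-fold lower number from compound 1 to compound 4 (1.28 log units; beyond the scatter). Compound 4 is therefore estimated at 1.2 nM, within a range from 0.4 nM to 4 nM.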

Compound 4, inhibition constant: 0.7 nM
Estimate against measurement, compound 4: 1.7-fold (0.23 log units) above; measured number inside the range.
By their numbers in this assay, from the lowest: compounds 4, 3 and 2 (each within the scatter of the next, the first and the last beyond it); then compound 1.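

In this assay, this position, on an aromatic carbon next to the ring nitrogen, takes a group carrying both a double bond and a six-membered ring of carbon and keeps the large gain over propyl, with a 32-fold lower number from compound 1 to compound 4 (1.51 log units; beyond the scatter). Putting cyclohexyl in place of the propyl end of the pent-1-en-1-yl chain leaves the result within the scatter, at a 1.3-fold lower number from compound 3 to compound 4 (0.11 log units; within the scatter), so the far end of the alkenyl group accepts either a ring or an open chain here. Against the group with two five-membered rings, the change gives a modest separation just beyond the scatter, with a 2.1-fold lower number from compound 2 to compound 4 (0.33 log units; beyond the scatter).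

No measurement shown here explains why these larger groups lower the number. The compounds shown leave open whether the double bond itself is needed, as 2-cyclohexylethyl is not among them, and whether a phenyl or an amine at the chain end would serve as well.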